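The compounds below may be only part of what the source reports. "The series", "measured", "known", "first", "only" and "open" are said of these compounds alone.

Measured compounds in a physicochemical assay for solubility, in phosphate buffer, with a stated time of 24 h, at pH 7.4; a higher number here means a more soluble compound, a lower number a less soluble compound. Compound 1 `COc1cncc(-c2cccc(-c3cn4cccc(C(N)=O)c4n3)c2)c1` gives < 1000 nM, which is a limit of the assay. Compound 2 `COc1cncc(-c2cccc(-c3cn4cccc(C(=O)N(C)C)c4n3)c2)c1` gives 10000 nM. Compound 3 `COc1cncc(-c2cccc(-c3cn4ccc(OC)c(C(N)=O)c4n3)c2)c1` gives 40000 nM.

Compound 3 stands highest of the two numbers shown; compound 2 gives the lower of the two, beyond the scatter. The third value, that of compound 1, is a limit rather than a number (the limit of < 1000 nM in this assay, at which 1 of the 3 values shown sits).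

Compound 4 `COc1ccn2cc(-c3cccc(-c4cncc(O[C@H]5CCOC5)c4)c3)nc2c1C(N)=O` differs from compound 3 in one place: oxolan-3-yl in place of methyl on an oxygen on an aromatic ring. The two measured steps touch other parts of the shared core. The step of an at least 10-fold higher number from compound 1 to compound 2 (1.00 log units; beyond the scatter) changes the carbonyl substituent; the step of an at least 40-fold higher number from compound 1 to compound 3 (1.60 log units; beyond the scatter) installs the methoxy whose methyl is now exchanged for the oxolan-3-yl. Among the measured compounds shown here, neither step tests a change on the ether oxygen itself, so no measured step bears directly on this one. The change enters one hydrogen-bond acceptor and a non-aromatic ring in place of a methyl; in the absence of a comparable step, a result within the scatter of compound 3 is expected, with room on either side.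

Compound 4 is therefore estimated at 40000 nM in this assay, within 15000 nM to 100000 nM, meaning an expected step of no change at the digits printed from compound 3 to compound 4 (within the scatter).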

Compound 4, solubility: 600000 nM
Estimate against measurement, compound 4: 15-fold (1.18 log units) below; measured number above the stated range.
By their numbers in this assay, from the lowest: compound 2; then compound 3; then compound 4. At a limit, below all of these: compound 1.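

In this assay, oxolan-3-yl in place of methyl on an oxygen on an aromatic ring gives a 15-fold higher number from compound 3 to compound 4 (1.18 log units; beyond the scatter). That oxygen carries a methyl in compound 1, compound 2 and compound 3 alike, so this is the first step shown that varies the group there, and it shows that this place also moves the number, with a ring, a hydrogen-bond acceptor and a defined stereocentre all entering in the one change. No measurement shown bears on why the number rises.

Which part of the oxolan-3-yl carries the step stays open: cyclopentyl would remove the ring oxygen while keeping a ring, an open chain such as 2-methoxyethyl would keep an ether oxygen without the ring, and the opposite stereoisomer of oxolan-3-yl would test the stereocentre. Also open, going by these compounds, is whether the same exchange gives a step of similar size on compound 2, which carries dimethylamino on the carbonyl carbon, and how a basic group such as a piperidine on the same oxygen would compare.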